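Hydroxymethyl Addition Carried From One Core to Another

This account rests on a few compounds, and the source may have more. Where it says the series, first, only, none or still open, it means among the compounds named here.

Measured compounds in an ADME assay on the whole organism (Rattus norvegicus) for pharmacokinetics; a higher number here means faster removal of the compound, a lower number slower removal:
compound 1, `COc1ccc(C(=O)C2=C(O)C(=O)N(c3ccc(-c4ccon4)cc3)C2c2ccccc2OC)cc1`, 8.8 mL/min/kg
compound 2, `COc1ccc(C(=O)C2=C(O)C(=O)N(c3ccc(-c4ccon4)cc3)C2c2ccccc2OCCO)cc1`, 67.6 mL/min/kg
compound 3, `COc1ccccc1C1C(C(=O)C(C)C)=C(O)C(=O)N1c1ccc(-c2ccsc2)cc1`, 0.3 mL/min/kg

Compound 1 and compound 2 share a core and differ in one place: hydroxymethyl in place of hydrogen on a saturated chain carbon bound to an oxygen on an aromatic ring. That change brought a 7.7-fold higher number from compound 1 to compound 2 (0.89 log units; beyond the scatter) in this assay. Compound 3 rests on a different core; the difference between the two cores is not broken down here. In this assay compound 3 gives 0.3 mL/min/kg, the lowest of the three numbers, far beneath compound 1 and further still beneath compound 2.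

Compound 4, `CC(C)C(=O)C1=C(O)C(=O)N(c2ccc(-c3ccsc3)cc2)C1c1ccccc1OCCO`, is not yet measured. It stands to compound 3 as compound 2 stands to compound 1: hydroxymethyl in place of hydrogen on a saturated chain carbon bound to an oxygen on an aromatic ring. The place is the same, word for word, so this is the same change, made on the second core. Among the compounds shown it occurs twice in all, and only one instance is measured.

The expectation for compound 4 rests on that single measured instance. Because a 7.7-fold higher number from compound 1 to compound 2 (0.89 log units; beyond the scatter) was seen on the first core, the same change on the core of compound 3 is expected to raise the number by a comparable step, estimated as a 6.7-fold higher number from compound 3 to compound 4 (0.82 log units; beyond the scatter), though with one example no more than a direction and rough size can be claimed. On that basis compound 4 is expected to give about 2 mL/min/kg in this assay, with a likely range from 0.5 mL/min/kg to 8 mL/min/kg.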

Compound 4, clearance: 3.9 mL/min/kg
For compound 4 the middle estimate is 2.0-fold (0.29 log units) below the measured one; the measured number falls inside the stated range.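

Made on the core of compound 3, the hydroxymethyl addition gave a 13-fold higher number from compound 3 to compound 4 (1.11 log units; beyond the scatter) in this assay and so moved the number in the same direction as on the core of compound 1. Set side by side, the two steps cannot be told apart in size: the same change on two cores in this assay, a 7.7-fold higher number (0.89 log units; beyond the scatter) from compound 1 to compound 2 and a 13-fold higher number (1.11 log units; beyond the scatter) from compound 3 to compound 4, 1.7-fold (0.23 log units) apart, within the scatter of two such steps. This suggests that, between these two cores, the change from 2-methoxyphenyl to 2-(2-hydroxyethoxy)phenyl carries over in both direction and rough size, but two pairs do not show that it would do so on any further core, and they give no reason for the rise.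

The compounds shown hold only methoxy and 2-hydroxyethoxy at this place, so they cannot separate the effect of the added chain carbon from that of the terminal hydroxyl, as an ethoxy group might. They also leave open how this assay would respond to a longer chain such as 3-hydroxypropoxy, or to an amine or a carboxylic acid at the end of the chain in place of the hydroxyl.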